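A Much Shorter Side Chain on Compound 3

The source may hold more compounds than are shown below. What is called first, only, known or untested is meant among the compounds shown, and "the series" means these compounds.

In a functional assay on HEL cells (Homo sapiens) (on this read-out higher numbers stand for lower toxicity in this test and lower numbers for higher toxicity in this test), compound 3 `CCCCCCCCc1cc2cn(COCCO)c(O)nc-2n1` gives 65000 nM. Compound 2 `CCCCCCCc1cc2cn(COCCO)c(O)nc-2n1` gives 119000 nM, and the step of a 1.8-fold lower number from compound 2 to compound 3 (0.26 log units; within the scatter) lies within the scatter. Compound 1 `CCCCCCCCCCc1cc2cn(COCCO)c(O)nc-2n1` gives 32000 nM, and the step of a 2.0-fold higher number from compound 1 to compound 3 (0.31 log units; beyond the scatter) lies just beyond it. Compound 3 therefore stands close to compound 2 and modestly apart from compound 1.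

Compound 4 `CCCCc1cc2cn(COCCO)c(O)nc-2n1` keeps the shared core but differs from compound 3 by hydrogen in place of butyl on a saturated chain carbon, four bonds along the chain from an aromatic carbon. This puts hydrogen in place of butyl on a saturated chain carbon, four bonds along the chain from an aromatic carbon.

Going by the values given here, two measured steps bear most directly on this change. Both shorten the chain and both are modest: a 2.0-fold higher number from compound 1 to compound 3 (0.31 log units; beyond the scatter) and a 3.7-fold higher number from compound 1 to compound 2 (0.57 log units; beyond the scatter). The cut to compound 4 goes further than either, so the trend is being extended beyond the measured chains, and three compounds support it only loosely. A moderate rise is expected, estimated as a 3.1-fold higher number from compound 3 to compound 4 (0.49 log units; beyond the scatter). For compound 4, the expected value is 200000 nM, with an estimated range of 90000 nM to 420000 nM.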

Compound 4, half-maximal cytotoxic concentration: > 200000 nM
Compound 4 gave a limit, no number (the forecaster's own chance of this, stated with the estimate: 35%); the middle value sits exactly at the limit.
By their numbers in this assay, from the lowest: compound 1; then compounds 3 and 2 (each within the scatter of the next). At a limit, above all of these: compound 4.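

In this assay compound 4 reads as a limit, not a number: the limit of > 200000 nM in this assay, at which 1 of the 4 values shown sits. Even so, the data give an at least 3.0-fold higher number from compound 3 to compound 4 (0.48 log units; beyond the scatter) and an at least 6.2-fold higher number from compound 1 to compound 4 (0.79 log units; beyond the scatter), so the downward cut in chain length at this position still raises the number clearly, and the trend seen among the longer chains reaches this much shorter one. The third comparison gives an at least 1.6-fold higher number from compound 2 to compound 4 (0.22 log units; that floor lies within the scatter), so that pair stays unresolved, and compounds 2 and 3 also lie within the scatter of each other, so the pattern holds across the four compounds but not at every step.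

As far as these compounds go, how far the true number for compound 4 lies past its limit remains open. So does whether a methyl group, or a chain ending in an amine or a carboxylic acid, would follow the same course.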